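Moving one chlorine: from compound 3 to compound 4

A few compounds are considered here, and "the series" means these few. Any claim that something is new, unique, unknown or untested is made for them only; others in the source may bear on it.

In a functional assay on MCF7 cells (Homo sapiens) for cytotoxicity, read by CellTiter-Glo, with a stated time of 5 days (a lower number here means a stronger inhibitor, a higher number a weaker inhibitor), compound 1 (`CC/C(=C(/c1ccc(/C=C/C(=O)O)cc1)c1cccc2[nH]ncc12)c1ccccc1`) gives 21 nM and compound 2 (`CC/C(=C(/c1ccc(/C=C/C(=O)O)nc1)c1ccc2[nH]ncc2c1)c1ccccc1`) gives 210 nM while compound 3 (`CC/C(=C(/c1ccc(/C=C/C(=O)O)cc1)c1ccc2[nH]ncc2c1)c1ccccc1Cl`) gives 2 nM as the lowest of the three numbers. Compound 3 therefore stands as the strongest inhibitor so far, and its lead over both others lies beyond the usual scatter of repeated measurements. These three differ from one another in more than one place, so none of them isolates a single change.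

Compound 4 (`CC/C(=C(/c1ccc(/C=C/C(=O)O)cc1)c1ccc2[nH]ncc2c1)c1ccc(Cl)cc1`) has the same atoms as compound 3, joined differently: 4-chlorophenyl in place of 2-chlorophenyl on a double-bonded chain carbon bound to a double-bonded chain carbon and a saturated chain carbon. Among the compounds with values here, no measured pair shows what this move does, so the expectation is cautious. Compound 3 at 2 nM is already low, which leaves more room to rise than to fall. In this assay the estimated step is a 3.0-fold higher number from compound 3 to compound 4 (0.48 log units; beyond the scatter) towards a weaker inhibitor and modest in size. For compound 4 the estimated value is 6 nM with an expected range from 1.5 nM to 30 nM in this measurement.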

Compound 4, half-maximal inhibitory concentration: 15 nM
Estimate against measurement, compound 4: 2.5-fold (0.40 log units) below, within the range that was stated.
By their numbers in this assay, from the lowest: compound 3; then compounds 4 and 1 (each within the scatter of the next); then compound 2.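

In this assay, within the data shown here, moving the chlorine gives a 7.5-fold higher number from compound 3 to compound 4 (0.88 log units; beyond the scatter), the first comparison here that isolates a single change. It shows that this position is sensitive to where the chlorine sits on the ring: the 2-chlorophenyl and 4-chlorophenyl groups have the same atoms and the same counts of hydrogen-bond donors and acceptors, yet the two compounds do not give the same number. Nothing available explains why the two arrangements differ.

The compounds shown hold no plain phenyl on the same core as compound 3, so what the chlorine itself contributes at this place remains open. Also open, as far as these compounds go, is how a different group at this place, such as 2-fluorophenyl or 2-methylphenyl, would compare with the 2-chlorophenyl of compound 3.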